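From iodo to methoxy on the shared core

The compounds below may be only part of what the source reports. "The series", "measured", "known", "first", "only" and "open" are said of these compounds alone.

Compound 1 `NC(=O)c1cc(Cl)ccc1NC(=O)COc1ccccc1`: 8140 nM
Compound 2 `NC(=O)c1cc(I)ccc1NC(=O)COc1ccccc1`: 1100 nM

In a functional assay on MOLT-4 cells (Homo sapiens) for inhibition (on this read-out lower numbers stand for stronger inhibition of growth and higher numbers for weaker inhibition of growth), compound 2 holds the lower of the two numbers. Compound 3 `COc1ccc(NC(=O)COc2ccccc2)c(C(N)=O)c1` differs from it by one change, (methoxy in place of iodo on an aromatic carbon), methoxy in place of iodo on an aromatic carbon. Going by the values given here, the one measured step that bears on this, a 7.4-fold lower number from compound 1 to compound 2 (0.87 log units; beyond the scatter), is modest and involves the same carbon. Among the compounds with values here, no methoxy compound has been measured, so a higher number of similar size is expected on losing the iodo. The expected step is a 5.5-fold higher number from compound 2 to compound 3 (0.74 log units; beyond the scatter). The estimate for compound 3 is 6000 nM, within an expected range of 1800 nM to 20000 nM.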

Compound 3, concentration for 50% growth inhibition: 2000 nM
Estimate against measurement, compound 3: 3.0-fold (0.48 log units) above; low and high end bracket the measured number.
By their numbers in this assay, from the lowest: compounds 2 and 3 (each within the scatter of the next); then compound 1.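

In this assay, methoxy replaces iodo with only a 1.8-fold higher number from compound 2 to compound 3 (0.26 log units; within the scatter) and so the step stays within the scatter, which shows that this carbon tolerates a change from a halogen to a group with an oxygen. Methoxy in place of chloro gives a 4.1-fold lower number from compound 1 to compound 3 (0.61 log units; beyond the scatter) as well, so the lower number relative to compound 1 is not confined to iodo. Nothing available accounts for this result.

On these data alone, whether an amine, a hydroxyl or a longer chain such as ethoxy at this carbon would stay close to compound 2 and compound 3 remains open.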